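Compound 3 to compound 4: a new group on nitrogen

The source may report more compounds than this note shows. Statements on the series, on what has been measured and on what is new or still open speak of the compounds shown alone.

In a functional assay on K562 cells (Homo sapiens) for cytotoxicity, read by trypan blue exclusion, with a stated time of 96 h (on this read-out higher numbers stand for weaker inhibition and lower numbers for stronger inhibition), compound 1 (`COc1ccc(N)cc1CS(=O)(=O)/C=C/c1c(OC)cccc1OC`) gives 25000 nM, compound 2 (`COc1cc(OC)c(/C=C/S(=O)(=O)Cc2ccc(Cl)cc2N)c(OC)c1`) gives 2500 nM and compound 3 (`COC(=O)CCNc1cc(CS(=O)(=O)/C=C/c2c(OC)cc(OC)cc2OC)ccc1OC`) gives 1000 nM. Compound 3 therefore has the lowest number of the three and the strongest inhibition, with both gaps beyond the usual scatter. Within the data shown here, compound 1 and compound 2 each differ from compound 3 in more than one place, so no measured pair isolates a single change.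

The next compound is compound 4 (`COC(=O)C(Nc1cc(CS(=O)(=O)/C=C/c2c(OC)cc(OC)cc2OC)ccc1OC)c1ccc(Cl)cc1`). In it, (4-chlorophenyl)(methoxycarbonyl)methyl stands in place of 2-(methoxycarbonyl)ethyl on a nitrogen on an aromatic ring: (4-chlorophenyl)(methoxycarbonyl)methyl in place of 2-(methoxycarbonyl)ethyl on a nitrogen on an aromatic ring. Among the measured compounds shown here, with no measured precedent for this exchange, the expectation is loose. The expected change is a 2.5-fold lower number from compound 3 to compound 4 (0.40 log units; beyond the scatter), a modest step towards stronger inhibition, although a result within the scatter remains possible. In this assay, the estimate for compound 4 is 400 nM, with an expected range of 80 nM to 2000 nM.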

Compound 4, half-maximal inhibitory concentration: 200 nM
Compound 4: middle estimate off by 2.0-fold (0.30 log units), on the high side; the range from low to high includes it.
By their numbers in this assay, from the lowest: compound 4; then compound 3; then compound 2; then compound 1.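

Among these compounds, this is the first comparison that isolates one place: in this assay, (4-chlorophenyl)(methoxycarbonyl)methyl in place of 2-(methoxycarbonyl)ethyl on a nitrogen on an aromatic ring gives a 5.0-fold lower number from compound 3 to compound 4 (0.70 log units; beyond the scatter). The substituent on this nitrogen therefore moves the read-out, and the entering group, with 12 heavy atoms against 6 and an added six-membered aromatic ring of carbon only, brings stronger inhibition, while the counts of hydrogen-bond donors and acceptors stay the same. No measurement available here accounts for the gain.

The aromatic ring and the chlorine enter together, so the compounds shown do not separate their shares in the step. Also open, as far as these compounds go, is whether an unsubstituted phenyl group, or a carboxylic acid in place of the methyl ester, would hold this level of inhibition at the same nitrogen.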